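Saturating the side-chain diene of a prostanoid ester

The source may report more compounds than this note shows. Statements on the series, on what has been measured and on what is new or still open speak of the compounds shown alone.

Compound 1 `C/C=C\C=C\[C@](C)(O)C/C=C/[C@H]1[C@H](O)CC(=O)[C@@H]1CC/C=C\CCC(=O)OC`: 0.0000099 mg/kg
Compound 2 `C=C/C=C/[C@](C)(O)C/C=C/[C@H]1[C@H](O)CC(=O)[C@@H]1CC/C=C\CCC(=O)OC`: 0.000007 mg/kg

Among the measured compounds shown here, in a functional assay on the whole organism with Canis familiaris (Canis lupus familiaris) as the target (a lower number here means that less compound is needed, a higher number that more compound is needed for the effect), compound 2 gives the lowest of the two numbers, its nearest neighbour being compound 1, and the only measured step, a 1.4-fold lower number from compound 1 to compound 2 (0.15 log units; within the scatter), is within the scatter. Compound 3 `CCCCC(C)(O)C/C=C/[C@H]1[C@H](O)CC(=O)[C@@H]1CC/C=C\CCC(=O)OC` differs from compound 2 by 1-hydroxy-1-methylpentyl in place of 1-hydroxy-1-methylpenta-2,4-dien-1-yl on a saturated chain carbon bound to a double-bonded chain carbon. For the measured compounds named here, no measured step touches this part of the structure, so nothing among the two values argues for a change beyond the scatter, and the estimate is held close to compound 2 with a wide range. Compound 3 is therefore expected at 0.00001 mg/kg, between 0.000003 mg/kg and 0.00004 mg/kg, a step of a 1.4-fold higher number from compound 2 to compound 3 (0.15 log units; within the scatter) in this assay.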

Compound 3, dose for half-maximal effect: 0.000023 mg/kg
The estimate for compound 3 lay 2.3-fold (0.36 log units) below the measured number; the measured number falls inside the stated range.
By their numbers in this assay, from the lowest: compounds 2 and 1 (each within the scatter of the next); then compound 3.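

In this assay, 1-hydroxy-1-methylpentyl in place of 1-hydroxy-1-methylpenta-2,4-dien-1-yl gives a 3.3-fold higher number from compound 2 to compound 3 (0.52 log units; beyond the scatter) and, in place of 1-hydroxy-1-methylhexa-2,4-dien-1-yl, gives a 2.3-fold higher number from compound 1 to compound 3 (0.37 log units; beyond the scatter) as well. Whereas the earlier step at the diene's end stayed within the scatter, removing both double bonds moves the number beyond it, modestly, and compound 3 needs more compound than either diene. Nothing available explains this shift. The compounds shown leave open how a chain with a single double bond would behave, and whether a phenyl group at the end of the chain would match the dienes.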